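A few compounds are considered here, and "the series" means these few. Any claim that something is new, unique, unknown or untested is made for them only; others in the source may bear on it.

Three compounds share one core and differ only in the group on a saturated ring carbon. Compound 1 `FC(F)(F)c1c(CN2CCC(c3ccccc3)CC2)ccn2c(CC3CC3)nnc12` carries a phenyl there, and in an assay on CHO cells for positive allosteric modulation of metabotropic glutamate receptor 2 (Homo sapiens), read by scintillation counting, with a stated time of 30 min (a lower number here means a smaller maximal response, a higher number a larger maximal response), compound 1 gives 261%. Compound 2 `Fc1cccc(F)c1C1CCN(Cc2ccn3c(CC4CC4)nnc3c2C(F)(F)F)CC1` gives 330%, and compound 3 `Fc1ccc(C2CCN(Cc3ccn4c(CC5CC5)nnc4c3C(F)(F)F)CC2)c(F)c1` gives 255%. Compound 1 thus stands second highest of the three: the step of a number 69 percentage points higher from compound 1 to compound 2 (beyond the scatter) lies beyond the scatter, the step of a number 6 percentage points lower from compound 1 to compound 3 (within the scatter) lies within it, and the step of a number 75 percentage points lower from compound 2 to compound 3 (beyond the scatter) is large.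

Compound 4 `Fc1ccc(COC2CCN(Cc3ccn4c(CC5CC5)nnc4c3C(F)(F)F)CC2)c(F)c1` has not yet been measured. It differs from compound 1 in one place: (2,4-difluorobenzyl)oxy in place of phenyl on a saturated ring carbon. The step of a number 6 percentage points lower from compound 1 to compound 3 (within the scatter) bears most on this, since the entering group carries the same two fluorines as the 2,4-difluorophenyl of compound 3, and that step stayed within the scatter. Among the compounds with values here, no measured pair shows what the rest of the entering group does to the largest response, so the range must be wide. A step within the scatter is therefore expected, a number 11 percentage points lower from compound 1 to compound 4 (beyond the scatter). Compound 4 is estimated to give 250%, between 180% and 320%.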

Compound 4, largest response reached (Emax), in percent of the reference or control that the assay uses in the metabotropic glutamate receptor 2 assay: 332%
Estimate against measurement, compound 4: 82 percentage points below; the measured number lies above the stated range.
By their numbers in the metabotropic glutamate receptor 2 assay, from the lowest: compounds 3 and 1 (each within the scatter of the next); then compounds 2 and 4 (each within the scatter of the next).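

In the metabotropic glutamate receptor 2 assay, (2,4-difluorobenzyl)oxy on this saturated ring carbon gives a number 71 percentage points higher from compound 1 to compound 4 (beyond the scatter) and a number 77 percentage points higher from compound 3 to compound 4 (beyond the scatter), so a 2,4-difluorinated ring that made no readable difference when attached directly to the saturated ring carbon goes with a large rise when carried by this group, and the same change also gives a number 2 percentage points higher from compound 2 to compound 4 (within the scatter), which shows that a second group can match 2,6-difluorophenyl at this position. In a physicochemical assay for solubility, read by HPLC, measured as kinetic solubility, at pH 4 (a lower number here means a less soluble compound, a higher number a more soluble compound), compound 1 gives > 100000 nM, which is a limit of the assay and not a number. In the physicochemical assay compound 4 gives > 100000 nM, also a limit, so the step between these two compounds cannot be read: the limit of > 100000 nM in the physicochemical assay, at which 2 of the 2 values shown sit.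

Still open, from the compounds shown here alone, is which part of the entering group goes with the rise, the oxygen, the added carbon or the fluorines. A plain benzyloxy group, a 2,4-difluorobenzyl group without the oxygen and a 2,6-difluorobenzyloxy group would each separate these parts.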